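Aryl exchange on the ring nitrogen: compound 3 to compound 4

A few compounds are considered here, and "the series" means these few. Any claim that something is new, unique, unknown or untested is made for them only; others in the source may bear on it.

The series shares the core seen in compound 1 `Nc1ccccc1NC(=O)c1ccc(CSC(=S)N2CCN(c3cccnc3)CC2)cc1`, compound 2 `Nc1ccccc1NC(=O)c1ccc(CSC(=S)N2CCc3cc(Cl)ccc32)cc1` and compound 3 `N#Cc1ccc(N2CCN(C(=S)SCc3ccc(C(=O)Nc4ccccc4N)cc3)CC2)cc1`. In a functional assay on MGC-803 cells (Homo sapiens) for antiproliferative activity, read by CCK-8 assay, with a stated time of 72 h, tested at 8 uM (a higher number here means a stronger effect of the compound at the concentration tested, a lower number a weaker effect), compound 1 gives 76.9%, compound 2 gives 82.2% and compound 3 gives 37.6%. Compound 3 stands lowest of the three; its nearest neighbour is compound 1, and the step of a number 39.3 percentage points lower from compound 1 to compound 3 (beyond the scatter) marks that gap, while compound 2 lies further above compound 3.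

Compound 4 `Nc1ccccc1NC(=O)c1ccc(CSC(=S)N2CCN(c3ccncc3)CC2)cc1` is not yet measured. It differs from compound 3 as follows: pyridin-4-yl in place of 4-cyanophenyl on an amine nitrogen in a ring. Among the compounds with values here, the only measured step that bears on this change is a number 39.3 percentage points lower from compound 1 to compound 3 (beyond the scatter), which ran in the opposite sense and was large. Compound 4 brings a pyridyl group back onto that ring nitrogen, though pyridin-4-yl rather than pyridin-3-yl, so a rise beyond the scatter is expected, of roughly the size lost before, with some allowance for the pyridin-4-yl not matching the pyridin-3-yl case exactly. Compound 4 is therefore expected to give 70%, between 50% and 85%, the expected step being a number 32.4 percentage points higher from compound 3 to compound 4 (beyond the scatter).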

Compound 4, a percentage reported as inhibition, at one concentration (the size of the read-out at that concentration, not a potency): 87.1%
Estimate against measurement, compound 4: 17.1 percentage points below; measured number above the stated range.
By their numbers in this assay, from the lowest: compound 3; then compounds 1, 2 and 4 (each within the scatter of the next, the first and the last beyond it).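

Pyridin-4-yl in place of 4-cyanophenyl on the amine nitrogen in the ring gives a number 49.5 percentage points higher from compound 3 to compound 4 (beyond the scatter) and so restores a high reading in this assay at this position. Among the three compounds that differ only here, the two pyridyl compounds stand above the 4-cyanophenyl compound, so the low reading of compound 3 belongs to that group and not to aryl substitution at this nitrogen in general. Where the ring nitrogen sits within the pyridyl group also registers, since pyridin-4-yl in place of pyridin-3-yl gives a number 10.2 percentage points higher from compound 1 to compound 4 (beyond the scatter) as a modest change. No supporting data bear on the origin of these steps.

Open, on these data alone, is whether the nitrile itself or the carbon-only aromatic ring accounts for the low reading of compound 3. Plain phenyl or pyridin-2-yl on this nitrogen would address that, and a single-concentration read-out leaves potency unresolved.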